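Notes on replacing acetyl with 3-fluorophenyl

The compounds below may be only part of what the source reports. "The series", "measured", "known", "first", "only" and "open" are said of these compounds alone.

Measured in an ADME assay on BHK cells (Mesocricetus auratus) for cytotoxicity, read by MTT assay, with a stated time of 96 h; on this read-out higher numbers stand for lower toxicity in this test and lower numbers for higher toxicity in this test (a sign marks a limit of the assay):
compound 1 `O=C(NC(=S)Nc1cccc(C(F)(F)F)c1)c1ccccc1` gives > 100000 nM as a limit
compound 2 `FC(F)(F)c1cccc(NC(=S)Nc2ccccc2)c1` gives 41000 nM as a number
compound 3 `CC(=O)NC(=S)Nc1cccc(C(F)(F)F)c1` gives > 100000 nM as a limit

Compound 3 stands at > 100000 nM as a limit of the assay, so its true starting point is not known.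

The next compound is compound 4 `Fc1cccc(NC(=S)Nc2cccc(C(F)(F)F)c2)c1` and the change leading to it is 3-fluorophenyl in place of acetyl on an amide-type nitrogen with 3-fluorophenyl in place of acetyl on an amide-type nitrogen. Among the compounds with values here, two measured steps bear on this. One is a step that the two limits leave unreadable from compound 1 to compound 3 and it gives no usable size. The other is an at least 2.4-fold higher number from compound 2 to compound 3 (0.38 log units; beyond the scatter) with acetyl in place of phenyl on an amide-type nitrogen, which is the closest measured change, run in the opposite sense. Within the data shown here, compound 2 at 41000 nM is also the only true number. The 3-fluorophenyl group itself has no measured value in this place, so the transfer is approximate.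

A lower number is expected, because an at least 2.4-fold higher number from compound 2 to compound 3 (0.38 log units; beyond the scatter) points that way when read backwards. The expected change is an at least 2.8-fold lower number from compound 3 to compound 4 (0.45 log units; beyond the scatter) in this assay and it is taken as at least modest. For compound 4 the estimated value is 35000 nM with an expected range from 12000 nM to 90000 nM in this read-out.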

Compound 4, half-maximal cytotoxic concentration: 9400 nM
Beside the measured number, compound 4's estimate is 3.7-fold (0.57 log units) above it, outside the stated range (below it).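

In this assay, placing 3-fluorophenyl on the amide-type nitrogen whose other neighbour is the thiocarbonyl carbon gives an at least 10-fold lower number from compound 3 to compound 4 (1.02 log units; beyond the scatter), and on this read-out the lower number stands for higher toxicity in this test. That size is only a minimum, because compound 3 stands at a limit of the assay rather than at a number: the limit of > 100000 nM in this assay, at which 2 of the 4 values shown sit. The step between the two compounds with an aromatic ring in this place is new and fully readable, as fluoro in place of hydrogen on an aromatic carbon gives a 4.4-fold lower number from compound 2 to compound 4 (0.64 log units; beyond the scatter), so the read-out responds to a change of a single atom on that ring and not only to the exchange of acetyl for a ring.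

Whether this drop belongs to fluoro in particular stays open, as the effect of a chloro or methoxy group on that ring, or of an amine or a carboxylic acid there, is not known from the compounds shown. As far as these compounds go, the true values of compound 1 and compound 3 also remain open, both being limits of the assay.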